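The compounds below may be only part of what the source reports. "The series", "measured", "known", "first", "only" and "open" are said of these compounds alone.

Measured compounds in a functional assay on HEK293 cells with D(4) dopamine receptor (Homo sapiens) as the target, read by FLIPR; a lower number here means a smaller maximal response, a higher number a larger maximal response:
- compound 1, `O/N=C(\CCN1CCN(c2ccccn2)CC1)c1ccccc1Cl`: 74%
- compound 2, `O/N=C(/CCN1CCN(c2ccccn2)CC1)c1ccccc1Cl`: 64%
- compound 3, `Cc1ccccc1/C(CCN1CCN(c2ccccn2)CC1)=N\O`: 72%

Compound 1 gives the top number of the three, but compound 3 and compound 2 both sit within the usual scatter of it, so the three do not separate in this assay.

Two steps connect the measured compounds. From compound 1 to compound 2 the change is a number 10 percentage points lower from compound 1 to compound 2 (within the scatter), which is within the scatter, and the only difference there is the fact that compounds 1 and 2 differ only in the configuration as drawn. From compound 2 to compound 3 the change is a number 8 percentage points higher from compound 2 to compound 3 (within the scatter), again within the scatter, for methyl in place of chloro on an aromatic carbon.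

The unmeasured compound 4, `O/N=C(\CCN1CCN(c2ccccn2)CC1)c1cccc(F)c1`, differs from compound 1 as 3-fluorophenyl in place of 2-chlorophenyl on a carbon with a double bond to nitrogen.

Neither measured step is this exact change, but the step from compound 2 to compound 3 is the one that alters the aryl substituent and it stayed within the scatter. Nothing in the series points to a step beyond the scatter in this assay for the exchange of one halogenated phenyl for another.

Compound 4 is therefore expected to give about 70% in this assay, with the likely range 55% to 85%. The expected step is a number 4 percentage points lower from compound 1 to compound 4 (within the scatter).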

Compound 4, largest response reached (reported as efficacy), in percent of the reference or control that the assay uses: 72%
Compound 4: middle estimate off by 2 percentage points, on the low side, and the stated range covers the measured number.
By their numbers in this assay, from the lowest: compounds 2, 3, 4 and 1 (each within the scatter of the next).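

In this assay, the exchange of 2-chlorophenyl for 3-fluorophenyl on the carbon with a double bond to nitrogen gives a number 2 percentage points lower from compound 1 to compound 4 (within the scatter), so compound 4 does not separate from compound 1. The earlier aryl step, a number 8 percentage points higher from compound 2 to compound 3 (within the scatter), covered only methyl in place of chloro, whereas this one changes both the halogen and its place in the group name, and the maximal response still stays within the scatter. The two changes are made together in a single step, and nothing given here assigns the small difference in the maximal response to either of them or explains why the response holds.

For the compounds shown here, the series so far holds only a narrow set of substituted phenyl groups at this carbon, so an unsubstituted phenyl, a methoxyphenyl or a phenyl carrying a carboxylic acid could still show whether any change here reaches beyond the scatter. From the compounds shown here alone, a longer chain in place of the saturated chain at the same carbon is also open, as is the opposite drawn configuration of compound 4.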